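Swapping a Chlorophenyl Amide for a tert-Butyl Amide

A few compounds are considered here, and "the series" means these few. Any claim that something is new, unique, unknown or untested is made for them only; others in the source may bear on it.

Compound 1 `O=C(Nc1ccc(Cl)cc1)c1c(NC(=O)C(F)(F)F)sc2c1CCCCC2` was examined in an ADME assay on THP-1 cells (Homo sapiens) for cytotoxicity; on this read-out lower numbers stand for higher toxicity in this test and higher numbers for lower toxicity in this test. In this assay compound 1 reaches only the limit of > 50000 nM, with no number beyond it. Compound 2 `COc1ccc(NC(=O)c2c(NC(=O)C(F)(F)F)sc3c2CCCC3)cc1` likewise reaches only the limit of > 50000 nM. Both values sit at the limit of > 50000 nM in this assay, at which 2 of the 2 values shown sit, so compound 1 stands at the boundary of what this assay reports, alongside compound 2. Compound 3 `CC(C)(C)NC(=O)c1c(NC(=O)C(F)(F)F)sc2c1CCCCC2` differs from compound 1 by tert-butyl in place of 4-chlorophenyl on an amide-type nitrogen. For the measured compounds named here, with both measured compounds at the limit, no step between them can be read. The expected step is a step that the limit leaves unreadable from compound 1 to compound 3, no shift beyond the scatter. Compound 3 is therefore estimated at about 60000 nM, between 25000 nM and 120000 nM.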

Compound 3, half-maximal cytotoxic concentration: > 50000 nM
Compound 3: a limit, no number; the forecaster's own chance of this, stated with the estimate: 80%; the middle value does not contradict the limit.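

No step can be read from compound 1 to compound 3, as both give a limit and not a number: the limit of > 50000 nM in this assay, at which 3 of the 3 values shown sit.

The compounds shown leave open whether tert-butyl in place of 4-chlorophenyl on an amide-type nitrogen changes this read-out at all.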